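The source may hold more compounds than are shown below. What is called first, only, known or untested is meant among the compounds shown, and "the series" means these compounds.

Measured so far:
compound 1 `C=Cc1cn([C@H]2C[C@H](O)[C@@H](CO)O2)c(=O)[nH]c1=O`: 14200 nM
compound 2 `Nc1ncnc2c1nnn2[C@@H]1C[C@H](CO)[C@@H](CO)[C@H]1CO`: > 200000 nM
Not yet measured: compound 3 `O=c1[nH]c(=O)n([C@H]2C[C@H](O)[C@@H](CO)O2)cc1C#CCCCO`

Going by the values given here, in an ADME assay on L1210/0 cells (Mus musculus) for cytotoxicity, with a stated time of 48 h (a lower number here means a stronger inhibitor, a higher number a weaker inhibitor), compound 1 gives 14200 nM as the only actual number so far. Compound 2 reads > 200000 nM and that is a limit of the assay, not a number.

Compound 3 differs from compound 1 at one place 5-hydroxypent-1-yn-1-yl in place of vinyl on an aromatic carbon with 5-hydroxypent-1-yn-1-yl in place of vinyl on an aromatic carbon. Among the compounds with values here, no step between measured compounds is available to size this change, so the expectation is loose. A weakening in this assay is expected, meaning a higher number and a move beyond the scatter, with compound 1 at 14200 nM as the sole anchor. The expected move is a 4.9-fold higher number from compound 1 to compound 3 (0.69 log units; beyond the scatter) on this estimate. Compound 3 is estimated at 70000 nM with an expected range from 15000 nM to 200000 nM for the coming measurement.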

Compound 3, half-maximal inhibitory concentration: > 200000 nM
Compound 3: a limit, no number; the forecaster's own chance of this, stated with the estimate: 30%; middle value at least 2.8-fold (0.45 log units) away from the limit.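

In this assay, this position on the aromatic carbon, two atoms from the ring nitrogen, does not tolerate every substituent: 5-hydroxypent-1-yn-1-yl in place of vinyl gives an at least 14-fold higher number from compound 1 to compound 3 (1.14 log units; beyond the scatter). Compound 3 reads > 200000 nM, which is a limit and not a number, so the step is a minimum size for this change. Any further weakening cannot be graded at this end of the scale: the limit of > 200000 nM in this assay, at which 2 of the 3 values shown sit.

Compound 3 brings in the triple bond, the longer chain and the hydroxyl in a single step, and the compounds shown do not separate these parts. On these data alone, it also remains open whether an unsubstituted ethynyl group, or a chain ending in an amine or a carboxylic acid, would read closer to compound 1 at this position.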